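An Indole in Place of a Phenyl Chain on a Shared Ester

This account rests on a few compounds, and the source may have more. Where it says the series, first, only, none or still open, it means among the compounds named here.

Measured in a functional assay on HBL-100 cells (Homo sapiens) for inhibition, read by sulforhodamine B assay, with a stated time of 48 h; a lower number here means a stronger inhibitor of growth, a higher number a weaker inhibitor of growth:
Compound 1 `O=C(CCCCCc1ccccc1)OCC1COCCOCCOCCOCCOCCO1` gives 64000 nM.
Compound 2 `O=C(OCC1COCCOCCOCCOCCOCCO1)c1cccc(-c2ccc(Br)cc2)c1` gives 6400 nM.
Compound 3 `O=C(OCC1COCCOCCOCCOCCOCCO1)c1cccnc1` gives only a limit of the assay, > 100000 nM.

Of the two actual numbers, compound 1 holds the higher one, and the gap down to compound 2 lies beyond the usual scatter. Compound 3 offers no number at all, only a limit.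

Compound 4 `O=C(CCCc1cc2ccccc2[nH]1)OCC1COCCOCCOCCOCCOCCO1` differs from compound 1 in one place: 1H-indol-2-yl in place of phenethyl on a saturated chain carbon, three bonds along the chain from a carbonyl carbon. Among the measured compounds shown here, only one measured step touches this part of the molecule, an at least 1.5-fold higher number from compound 1 to compound 3 (0.19 log units; that floor lies within the scatter), and it exchanges the whole phenylpentyl chain for a single ring, ending at the limit (the limit of > 100000 nM in this assay, at which 1 of the 3 values shown sits). That step is not the same kind of change, since compound 4 keeps a saturated chain and swaps one aromatic ring for another. With no closer comparison at hand, a step in this assay beyond the scatter is not expected in either direction. Compound 4 is therefore estimated at 50000 nM, within a range from 15000 nM to 150000 nM. The expected step of a 1.3-fold lower number from compound 1 to compound 4 (0.11 log units; within the scatter) amounts to none beyond the scatter.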

Compound 4, concentration for 50% growth inhibition: > 100000 nM
Compound 4: no number, only a limit; the forecaster's own chance of this, stated with the estimate: 30%; at least 2.0-fold (0.30 log units) between middle value and limit.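

In this assay, among the compounds shown here, placing 1H-indol-2-yl in place of phenethyl, with the saturated chain kept, gives an at least 1.5-fold higher number from compound 1 to compound 4 (0.19 log units; that floor lies within the scatter) as the only reading of this change. It is the first change shown that keeps the chain and exchanges only its aromatic end, and it brings no measurable gain in growth inhibition, although the floor of the step does not separate the two compounds. The result for compound 4 is a limit and not a number, and compound 3 stands at the same limit: the limit of > 100000 nM in this assay, at which 2 of the 4 values shown sit.

As far as these compounds go, the real size of this step stays open, since a limit marks no endpoint. Also open, from the compounds shown here alone, is whether another end on this chain, such as an amine or a carboxylic acid, or a longer chain carrying the 1H-indol-2-yl group, would bring the number down.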